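The compounds below may be only part of what the source reports. "The series", "measured", "known", "first", "only" and "open" are said of these compounds alone.

Of the compounds shown here, two share a core and have been measured in an assay on HEK293 cells for inhibition of Voltage-dependent T-type calcium channel subunit alpha-1G (Homo sapiens), read by patch clamp; on this read-out lower numbers stand for stronger inhibition and higher numbers for weaker inhibition. Compound 1 `CN(CCCCCN1CCCC1)C1=Nc2ccccc2C(CC(=O)NCc2ccccc2)N1c1ccccc1` gives 4200 nM in this assay. Compound 2 `COC(=O)CC1c2ccccc2N=C(N(C)CCCCCN2CCCC2)N1c1ccccc1` differs only at the carbonyl carbon, where a methoxy replaces the benzylamino group of compound 1; in this assay compound 2 gives 5840 nM. The step of a 1.4-fold higher number from compound 1 to compound 2 (0.14 log units; within the scatter) lies within the scatter, so these two numbers cannot be told apart. Compound 1 thus stands at one end of two numbers that sit within the scatter of each other, with compound 2 nearest to it.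

Compound 3 `CN(CCCCCN1CCCC1)C1=Nc2ccccc2C(CC(=O)NCc2ccccc2)N1c1ccc(-c2ccccc2)cc1` has not yet been measured. It differs from compound 1 by phenyl in place of hydrogen on an aromatic carbon. Within the data shown here, the only measured step, from compound 1 to compound 2, touches a different part of the molecule, the carbonyl carbon, and says nothing about adding a phenyl group on the ring. Among the measured compounds shown here, with no step bearing on this change, the data give no ground to expect a shift in this assay beyond the scatter in either direction. Compound 3 is therefore expected to give about 3500 nM in this assay, with a range from 1000 nM to 12000 nM. The step this estimate means, a 1.2-fold lower number from compound 1 to compound 3 (0.08 log units; within the scatter), is expected to be small.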

Compound 3, half-maximal inhibitory concentration: 260 nM
Compound 3: the middle estimate sits 13-fold (1.13 log units) above what was measured; the measured number lies below the stated range.
By their numbers in this assay, from the lowest: compound 3; then compounds 1 and 2 (each within the scatter of the next).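

In this assay, among these compounds, the aromatic ring that carries the new group proves far more responsive than the carbonyl carbon: phenyl in place of hydrogen on an aromatic carbon, para to a large group, turns phenyl into 4-phenylphenyl and brings a 16-fold lower number from compound 1 to compound 3 (1.21 log units; beyond the scatter), whereas the only earlier step, at the carbonyl carbon, stayed within the scatter. Among the compounds shown here, the earlier compounds left this ring unchanged, so this is the first sign that the structure can be changed here with a large effect on the number, and the group that does it is a carbon-only aromatic ring with no hydrogen-bond donors, no hydrogen-bond acceptors and no net charge. Nothing available here accounts for the size of this step, so it stands as an observation without a stated cause.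

The compounds shown leave open whether a whole ring is needed at this place, or whether a smaller group such as methyl or chlorine, or a nitrogen-containing ring such as pyridyl, would give a similar step. They also leave open whether 4-phenylphenyl would have the same effect with the methyl ester of compound 2 in place of the benzyl amide.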